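The source may report more compounds than this note shows. Statements on the series, on what has been measured and on what is new or still open speak of the compounds shown alone.

Measured compounds and values

- compound 1 `CS(=O)(=O)CCNC(=O)Nc1cc2c(Nc3ccc(F)c(Cl)c3)ncnc2cc1O[C@H]1CCOC1` gives 1570 nM in a functional assay on A-431 cells (Homo sapiens) for antiproliferative activity, read by sulforhodamine B assay, with a stated time of 72 h; a lower number here means a stronger inhibitor, a higher number a weaker inhibitor
- compound 2 `CN(C)CCNC(=O)Nc1cc2c(Nc3ccc(F)c(Cl)c3)ncnc2cc1O[C@H]1CCOC1` gives 806 nM in this assay
- compound 3 `O=C(Nc1cc2c(Nc3ccc(F)c(Cl)c3)ncnc2cc1O[C@H]1CCOC1)N1CCC(CCO)CC1` gives 759 nM in this assay

Compound 3 has the lowest number of the three. One step to it, a 1.1-fold lower number from compound 2 to compound 3 (0.03 log units; within the scatter), is within the scatter; only the other, a 2.1-fold lower number from compound 1 to compound 3 (0.32 log units; beyond the scatter), is beyond it. Between the remaining pair the step is a 1.9-fold lower number from compound 1 to compound 2 (0.29 log units; within the scatter), again within the scatter. All three share the same core and differ only in the substituent on the carbonyl carbon of the urea.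

Compound 4 `C#CCNC(=O)Nc1cc2c(Nc3ccc(F)c(Cl)c3)ncnc2cc1O[C@H]1CCOC1` differs from compound 3 in the same place: propargylamino in place of 4-(2-hydroxyethyl)piperidin-1-yl on a carbonyl carbon. Within the data shown here, the steps that bear on this change are the two that replace the carbonyl substituent, a 2.1-fold lower number from compound 1 to compound 3 (0.32 log units; beyond the scatter) and a 1.1-fold lower number from compound 2 to compound 3 (0.03 log units; within the scatter); together they show that three quite different substituents on this carbonyl give numbers within a narrow band. Among the measured compounds shown here, no measured step introduces a propargylamino group, so its own effect is untested. The expectation is a change in this assay no larger than the measured steps, if anything a modest rise toward the number of compound 1. The expected step is a 1.4-fold higher number from compound 3 to compound 4 (0.16 log units; within the scatter). Compound 4 is therefore estimated at 1100 nM, with a range from 450 nM to 2700 nM.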

Compound 4, half-maximal inhibitory concentration: 3730 nM
Estimate against measurement, compound 4: 3.4-fold (0.53 log units) below, outside the stated range (above it).
By their numbers in this assay, from the lowest: compounds 3, 2 and 1 (each within the scatter of the next, the first and the last beyond it); then compound 4.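

In this assay the narrow band seen so far on this carbonyl carbon does not hold for propargylamino: a 4.9-fold higher number from compound 3 to compound 4 (0.69 log units; beyond the scatter) and a 4.6-fold higher number from compound 2 to compound 4 (0.67 log units; beyond the scatter) are both steps up, and both lie beyond the scatter. Compound 1 does not close the gap either, with a 2.4-fold higher number from compound 1 to compound 4 (0.38 log units; beyond the scatter) as the remaining step, so compound 4 is the weakest of the four and the substituent on this carbonyl carbon does matter in this series. Nothing shown gives a cause for this rise.

From the compounds shown here alone, it remains open whether the rise follows the triple bond or the short chain, and the saturated propylamino group would separate the two. An unsubstituted piperidin-1-yl group would likewise show how much of the number of compound 3 depends on its 2-hydroxyethyl group.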